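Aryl variation on the triazolylmethyl arm of the series

A few compounds are considered here, and "the series" means these few. Any claim that something is new, unique, unknown or untested is made for them only; others in the source may bear on it.

Compound 3 `CCOc1ccccc1-n1nncc1CN1C(=O)C2(C(C#N)=C(N)Oc3c2c2nc4ccccc4nc2c2ccccc32)c2ccccc21` in a functional assay on A549 cells (Homo sapiens) for antiproliferative activity, read by MTT assay, with a stated time of 48 h (a lower number here means a stronger inhibitor, a higher number a weaker inhibitor), gives > 50000 nM, which is a limit of the assay and not a number. Compound 1 `N#CC1=C(N)Oc2c(c3nc4ccccc4nc3c3ccccc23)C12C(=O)N(Cc1cnnn1-c1ccc(F)cc1)c1ccccc12` gives > 50000 nM in this assay, again only a limit. Compound 2 `COc1ccc(-n2nncc2CN2C(=O)C3(C(C#N)=C(N)Oc4c3c3nc5ccccc5nc3c3ccccc43)c3ccccc32)cc1` in this assay likewise returns a limit, > 50000 nM. For the measured compounds named here, every value so far rests at the limit of > 50000 nM in this assay, at which 3 of the 3 values shown sit, so the steps a step that the two limits leave unreadable from compound 1 to compound 2, a step that the two limits leave unreadable from compound 1 to compound 3 and a step that the two limits leave unreadable from compound 2 to compound 3 carry no readable size or direction; they show only that methoxy in place of fluoro, and 2-ethoxyphenyl in place of 4-fluorophenyl or 4-methoxyphenyl, left the series at the limit.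

Compound 4 `Cc1ccc(C)c(-n2nncc2CN2C(=O)C3(C(C#N)=C(N)Oc4c3c3nc5ccccc5nc3c3ccccc43)c3ccccc32)c1` is the next member. The change from compound 3 is 2,5-dimethylphenyl in place of 2-ethoxyphenyl on an aromatic nitrogen, so the ether oxygen goes and two methyl groups come, on the same aromatic nitrogen of the triazole. Going by the values given here, no measured step on this arm has moved any compound off the limit, and no step among the three bears a readable size that could be carried over.

For compound 4 the expectation is therefore that this assay again reports a limit, with the estimated step of a number no higher from compound 3 to compound 4 (the limit leaves the size open) meaning no change beyond the scatter. The estimate for compound 4 is 50000 nM, expected within 20000 nM to 200000 nM.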

Compound 4, half-maximal inhibitory concentration: > 50000 nM
Compound 4 ended at the assay's limit; the forecaster's own chance of this, stated with the estimate: 85%; the middle value lies on the limit itself.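

Compound 4 gives > 50000 nM in this assay, which is a limit of the assay and not a number. Its steps from compound 1, compound 2 and compound 3 cannot be read in size or direction, since the whole set rests at one limit: the limit of > 50000 nM in this assay, at which 4 of the 4 values shown sit.

The compounds shown leave open whether any aryl group on this arm moves a compound off the limit.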